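The source may hold more compounds than are shown below. What is called first, only, known or untested is meant among the compounds shown, and "the series" means these compounds.

Series notes. The shared core is that of compound 1 `COc1cnc(O[C@@H]2C[C@H]3C(=O)N[C@]4(C(=O)NS(=O)(=O)C5CC5)C[C@H]4/C=C\CCCC[C@@H](C)[C@H](NC(=O)OC(C)(C)C(F)(F)F)C(=O)N3C2)c2ccccc12`. In an ADME assay on microsomes from liver (Homo sapiens) for metabolic stability, read by LC-MS, using NADPH, with a stated time of 45 min (a lower number here means that the compound disappears faster, a higher number that the compound lasts longer), compound 1 gives 0.31 h. Compound 2 `COc1cnc(O[C@@H]2C[C@H]3C(=O)N[C@]4(C(=O)NS(=O)(=O)C5CC5)C[C@H]4/C=C\CC[C@@H](C)C[C@@H](C)[C@H](NC(=O)OC(C)(C)C(F)(F)F)C(=O)N3C2)c2ccccc12` carries a methyl in place of hydrogen on a saturated ring carbon; in this assay compound 2 gives 0.198 h. For the measured compounds named here, the step of a 1.6-fold lower number from compound 1 to compound 2 (0.19 log units; within the scatter) is the only single-point change measured in this set, and it lies within the scatter. Compound 3 `COc1cnc(O[C@@H]2C[C@H]3C(=O)N[C@]4(C(=O)NS(=O)(=O)C5(C)CC5)C[C@H]4/C=C\CC[C@@H](C)C[C@@H](C)[C@H](NC(=O)OC(C)(C)C(F)(F)F)C(=O)N3C2)c2ccccc12`, measured more than once, gives in this assay 0.25 h; 0.3 h (2 entries); this repeated record the several entries of compound 3 in this assay, 0.25 h; 0.3 h (2 entries) shows how closely repeat measurements of one compound agree. Compound 2 thus stands within the scatter of compound 1 on the numbers shown, and the entries of compound 3 fall in the same band.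

Compound 4 `CC[C@@H]1C[C@H](C)CC/C=C\[C@@H]2C[C@@]2(C(=O)NS(=O)(=O)C2CC2)NC(=O)[C@@H]2C[C@@H](Oc3ncc(OC)c4ccccc34)CN2C(=O)[C@H]1NC(=O)OC(C)(C)C(F)(F)F` is not yet measured. It differs from compound 2 by methyl in place of hydrogen on a saturated chain carbon bound to a saturated ring carbon. Going by the values given here, no measured step in this set alters that chain carbon; the nearest comparison is the methyl added on a saturated ring carbon in the step of a 1.6-fold lower number from compound 1 to compound 2 (0.19 log units; within the scatter), which stayed within the scatter. A step of that order, or none beyond the scatter, is therefore expected, a 1.0-fold higher number from compound 2 to compound 4 (0.00 log units; within the scatter). For compound 4 in this assay the expected half-life is 0.2 h, with a range from 0.1 h to 0.4 h.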

Compound 4, half-life: 0.628 h
Estimate against measurement, compound 4: 3.1-fold (0.50 log units) below; the measured number lies above the stated range.
By their numbers in this assay, from the lowest: compounds 2 and 1 (each within the scatter of the next); then compound 4.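

Methyl in place of hydrogen on a saturated chain carbon bound to a saturated ring carbon, which reads as methyl to ethyl when cut one bond further out, gives a change that can be read in this assay: a 3.2-fold higher number from compound 2 to compound 4 (0.50 log units; beyond the scatter). The earlier methyl change on a saturated ring carbon, a 1.6-fold lower number from compound 1 to compound 2 (0.19 log units; within the scatter), gave no such reading, so among these two steps only the one at the chain carbon lies beyond the scatter, and a single added methyl cannot be treated as neutral in this series. The new step also stands apart from the agreement seen between repeats of a single compound: the several entries of compound 3 in this assay, 0.25 h; 0.3 h (2 entries)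

These compounds give no cause for the higher half-life of compound 4, and one step at this carbon cannot show whether the change would carry over to other members of the series. Also open, on these data alone, is how the half-life would respond to a longer chain such as propyl, or to a hydroxyl or an amine on the same chain carbon.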